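The source may report more compounds than this note shows. Statements on the series, on what has been measured and on what is new or still open speak of the compounds shown alone.

Measured so far:
Compound 1 `COc1cccc(/C=C/C(=O)Nc2cc(OC)c(OC)c(OC)c2)c1`: 16500 nM
Compound 2 `C=C(Br)C(=O)Nc1cccc(/C=C/C(=O)Nc2cccc3ccccc23)c1`: 1400 nM
Compound 3 `C=C(Br)C(=O)Nc1cccc(/C=C/C(=O)Nc2ccc(Cl)cc2)c1`: 2800 nM

In a functional assay on HeLa cells (Homo sapiens) for inhibition, read by MTT assay, with a stated time of 72 h (on this read-out lower numbers stand for stronger inhibition and higher numbers for weaker inhibition), compound 3 gives 2800 nM. That value lies within the usual scatter of repeated measurements of compound 2 at 1400 nM, so these two cannot be told apart. Against compound 3, compound 1 shows a clearly higher number, 16500 nM, and this gap lies beyond the scatter.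

The next compound to be tested is compound 4 `C=C(Br)C(=O)Nc1cccc(/C=C/C(=O)Nc2ccc(SC(F)(F)F)cc2)c1`. It matches compound 3 except at one place, with (trifluoromethyl)sulfanyl in place of chloro on an aromatic carbon.

Within the data shown here, no measured pair here shows this exchange on its own, so its size can only be expected. The closest guide is a comparison of two different aromatic ends: compound 3 at 2800 nM and compound 2 at 1400 nM remain within the scatter of each other. A change at that end may therefore move the number little, although two compounds are thin evidence. The expected result is a slightly lower number, with no change beyond the scatter, and the estimated step is a 1.4-fold lower number from compound 3 to compound 4 (0.15 log units; within the scatter).

For compound 4 the estimated value in this assay is 2000 nM, with an expected range of 800 nM to 5000 nM.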

Compound 4, half-maximal inhibitory concentration: 19000 nM
For compound 4 the middle estimate is 9.5-fold (0.98 log units) below the measured one; measured number outside the range, above it.
By their numbers in this assay, from the lowest: compounds 2 and 3 (each within the scatter of the next); then compounds 1 and 4 (each within the scatter of the next).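

In this assay, putting (trifluoromethyl)sulfanyl in place of chloro on this aromatic carbon gives a 6.8-fold higher number from compound 3 to compound 4 (0.83 log units; beyond the scatter), a move toward weaker inhibition that lies beyond the usual scatter. Among these compounds, this is the first comparison in the set in which only one place changes, and it shows that the group on this carbon, para to a large group, can shift the number clearly while the rest of the molecule stays the same. The exchange swaps one chlorine atom for a group of five heavy atoms containing carbon, sulfur and fluorine, but no measurement here explains why the number rises.

Going by these compounds, with only chloro and (trifluoromethyl)sulfanyl to compare at this carbon, it remains open whether the sulfur or the fluorines matter more, a question that a plain trifluoromethyl or a methylsulfanyl group could help to separate. Also open, on these data alone, are the effects of a methyl group, an amine or a carboxylic acid at the same carbon, and whether this exchange would produce a similar step on a different core.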